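The compounds below may be only part of what the source reports. "The series", "measured", "known", "first", "only" and "open" are said of these compounds alone.

Three compounds built on a shared core have numbers in a functional assay on HO8910 cells (Homo sapiens) for inhibition, read by MTT assay, with a stated time of 24 h, tested at 100 ug/mL; a higher number here means more inhibition of growth at the concentration tested, a lower number less inhibition of growth. Compound 1 `O=C(CCCCC1CCSS1)Nc1ccc(OC(F)(F)F)cc1` gives 84.5%, compound 2 `O=C(CCCCC1CCSS1)Nc1ccccn1` gives 51.9%, and compound 3 `O=C(CCCCC1CCSS1)Nc1ccc(Cl)cn1` gives 68.6%. Compound 3 therefore stands second of the three, and its distance to each of the other two lies beyond the usual scatter of such measurements.

Compound 4 `O=C(CCCCC1CCSS1)Nc1ccc(Br)cn1` has no number yet. It differs from compound 3 in one place: bromo in place of chloro on an aromatic carbon. Put simply, this is bromo in place of chloro on an aromatic carbon.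

Among the compounds with values here, one measured step bears on this change, a number 16.7 percentage points higher from compound 2 to compound 3 (beyond the scatter). That step, chloro in place of hydrogen on an aromatic carbon, is modest but beyond the scatter, and it occurs at the same place on the ring. It compares a halogen with no halogen, however, whereas compound 4 only exchanges one halogen for another. Within the data shown here, no measured pair shows such an exchange, so the evidence is indirect. A much smaller step is therefore expected, perhaps slightly upward, and none beyond the scatter. The expected step is a number 3.4 percentage points higher from compound 3 to compound 4 (within the scatter). For compound 4 the estimated value is 72%, with an expected range of 60% to 84%.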

Compound 4, percent growth inhibition at one concentration: 32.1%
The estimate for compound 4 lay 39.9 percentage points above the measured number, and the stated range ends above it.
By their numbers in this assay, from the lowest: compound 4; then compound 2; then compound 3; then compound 1.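

In this assay, the two halogens are not interchangeable at this place on the ring, two atoms from the ring nitrogen. Exchanging chloro for bromo swaps one heavy atom for one heavy atom, with no change in the counts of hydrogen-bond donors or acceptors and no net charge, yet it gives a number 36.5 percentage points lower from compound 3 to compound 4 (beyond the scatter). Measured against hydrogen, the two halogens also pull in opposite directions: chloro gives a number 16.7 percentage points higher from compound 2 to compound 3 (beyond the scatter), whereas bromo gives a number 19.8 percentage points lower from compound 2 to compound 4 (beyond the scatter), so adding a halogen here does not by itself raise the number, and no available measurement accounts for this reversal.

With only hydrogen, chloro and bromo compared at this place, the compounds shown cannot tell whether a fluoro group, an iodo group, a methoxy group or an amine would follow compound 3 or compound 4. They also leave open whether the gap between chloro and bromo would hold at other concentrations, since each compound is represented by a single tested concentration.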